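Ester Chain Length and Cytotoxicity in HeLa Cells

The source may hold more compounds than are shown below. What is called first, only, known or untested is meant among the compounds shown, and "the series" means these compounds.

Measured so far:
- compound 1, `CC(=O)O[C@]12C=CC(=O)C[C@H]1OCC2`: 4.1 ug/mL
- compound 2, `CCCC(=O)O[C@]12C=CC(=O)C[C@H]1OCC2`: 2.7 ug/mL
- compound 3, `CCCC(=O)O[C@]12C=CC(O)C[C@H]1OCC2`: 8.8 ug/mL

All three were tested in a functional assay on HeLa S3 cells (Homo sapiens) for cytotoxicity; on this read-out lower numbers stand for stronger inhibition and higher numbers for weaker inhibition. Compound 2 differs from compound 1 by ethyl in place of hydrogen on a saturated chain carbon bound to a carbonyl carbon, a change that produced a 1.5-fold lower number from compound 1 to compound 2 (0.18 log units; within the scatter). Compound 3 carries a different core from compound 1; the difference between the two cores is not broken down here. Compound 3 gives the highest number of the three, and its gaps to compound 1 and to compound 2 both lie beyond the scatter.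

Compound 4, `CCCCCC(=O)O[C@]12C=CC(O)C[C@H]1OCC2`, has not yet been measured. It differs from compound 3 by ethyl in place of hydrogen on a saturated chain carbon, three bonds along the chain from a carbonyl carbon. This is the same kind of change as that from compound 1 to compound 2, but not the same: there the ethyl entered on a saturated chain carbon bound to a carbonyl carbon, whereas here it enters three bonds along the chain from a carbonyl carbon. In this assay the step for compound 4 is expected to be small, a 1.4-fold lower number from compound 3 to compound 4 (0.13 log units; within the scatter), because a 1.5-fold lower number from compound 1 to compound 2 (0.18 log units; within the scatter) stayed within the scatter. The estimate for compound 4 is therefore 6.5 ug/mL, likely between 3 ug/mL and 15 ug/mL.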

Compound 4, half-maximal inhibitory concentration: 5.3 ug/mL
For compound 4 the middle estimate is 1.2-fold (0.09 log units) above the measured one; measured number inside the range.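

In this assay, adding the ethyl on the second core gives a 1.7-fold lower number from compound 3 to compound 4 (0.22 log units; within the scatter), so the step stays small here just as it did on the first core. Set side by side, the two steps agree, which means this change carried over from one core to the other without a visible difference in size: the same change on two cores in this assay, a 1.5-fold lower number (0.18 log units; within the scatter) from compound 1 to compound 2 and a 1.7-fold lower number (0.22 log units; within the scatter) from compound 3 to compound 4, 1.1-fold (0.04 log units) apart, within the scatter of two such steps This does not show that lengthening the chain truly strengthens the effect on cells, since each step on its own lies within the scatter, and two pairs say nothing about any further core; the ethyl also enters at a different place along the chain in each pair.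

The compounds shown leave open how the pentyl chain would behave on the core of compound 1, and whether a still longer chain would finally move the number beyond the scatter. They also leave open what an amine or a carboxylic acid at the end of the chain would do on either core.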